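Swapping the amide aryl group on a flavonol anilide series

The compounds below may be only part of what the source reports. "The series", "measured", "known", "first", "only" and "open" are said of these compounds alone.

Measured compounds in a functional assay on MCF7 cells (Homo sapiens) for antiproliferative activity, read by CCK-8 assay, with a stated time of 72 h; on this read-out lower numbers stand for stronger inhibition and higher numbers for weaker inhibition:
compound 1 `O=C(Nc1cccc(-c2oc3cc(-c4ccc(F)cc4)ccc3c(=O)c2O)c1)c1ccc(Cl)cc1` – 4730 nM
compound 2 `Cc1ccccc1C(=O)Nc1cccc(-c2oc3cc(-c4ccc(F)cc4)ccc3c(=O)c2O)c1` – 2280 nM
compound 3 `O=C(Nc1cccc(-c2oc3cc(-c4ccc(F)cc4)ccc3c(=O)c2O)c1)c1ccc(Br)cc1` – 24000 nM

Compound 3 stands at the highest number of the three, with compound 1 nearest to it and compound 2 furthest away. Compound 4 `COc1cccc(C(=O)Nc2cccc(-c3oc4cc(-c5ccc(F)cc5)ccc4c(=O)c3O)c2)c1` differs from compound 3 in a single place: 3-methoxyphenyl in place of 4-bromophenyl on a carbonyl carbon.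

Among the compounds with values here, two measured steps bear on this change, since both alter the same aryl group on the carbonyl carbon. The step of a 5.1-fold higher number from compound 1 to compound 3 (0.71 log units; beyond the scatter) and the step of an 11-fold higher number from compound 2 to compound 3 (1.02 log units; beyond the scatter) both show that compound 3, carrying the 4-bromophenyl, gives the highest number of the set, while the other two aryl groups tried in this position gave lower numbers. Neither step tests a methoxy substituent, and none of the three compounds places a substituent in the position the methoxy occupies here, so the size of the expected move is uncertain. Still, replacing the 4-bromophenyl with a different aryl group has lowered the number each time it was measured, and compound 4 is therefore expected to follow the same direction, with an estimated step of a 5.3-fold lower number from compound 3 to compound 4 (0.73 log units; beyond the scatter). The estimate for compound 4 in this assay is 4500 nM, within a range from 1500 nM to 14000 nM.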

Compound 4, half-maximal inhibitory concentration: 15300 nM
Compound 4: the middle estimate sits 3.4-fold (0.53 log units) below what was measured; the measured number lies above the stated range.
By their numbers in this assay, from the lowest: compound 2; then compound 1; then compounds 4 and 3 (each within the scatter of the next).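

In this assay, the 3-methoxyphenyl on the carbonyl carbon cannot be told apart from the 4-bromophenyl (a 1.6-fold lower number from compound 3 to compound 4 (0.20 log units; within the scatter)), so replacing the 4-bromophenyl does not always shift the number beyond the scatter. The 3-methoxyphenyl also gives a higher number than the 2-methylphenyl (a 6.7-fold higher number from compound 2 to compound 4 (0.83 log units; beyond the scatter)) and the 4-chlorophenyl (a 3.2-fold higher number from compound 1 to compound 4 (0.51 log units; beyond the scatter)), which leaves these two groups with the lowest numbers among the four compounds. Nothing in the data shown accounts for these differences.

Going by these compounds, whether the methoxy group itself or its place on the aryl ring sets the number for compound 4 remains open. So does whether a dimethylamino group or a carboxylic acid on this aryl ring would give a number nearer to that of compound 2.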